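This account rests on a few compounds, and the source may have more. Where it says the series, first, only, none or still open, it means among the compounds named here.

In a functional assay on CLL cells (Homo sapiens) for cytotoxicity, read by MTT assay, with a stated time of 48 h (on this read-out higher numbers stand for an effect only at larger amounts of compound and lower numbers for an effect already at smaller amounts), compound 1 `C=C(CC)C(=O)c1ccc(OCC(=O)Nc2ccc(C(=O)O)cc2)c(Cl)c1Cl` gives 5000 nM and compound 2 `C=C(CC)C(=O)c1ccc(OCC(=O)Nc2ccc(/C=C/C(=O)NO)cc2)c(Cl)c1Cl` gives 2600 nM. Going by the values given here, these are the only two numbers so far, and they lie within the scatter of each other, so compound 2 cannot be separated from compound 1. Compound 3 `C=C(CC)C(=O)c1ccc(OCC(=O)Nc2ccc(/C=C/C(=O)OCC)cc2)c(Cl)c1Cl` keeps the rest of compound 2 and alters only its end group, with ethoxy in place of hydroxyamino on a carbonyl carbon. Among the compounds with values here, no measured step covers this exact change. The only one touching this end of the molecule is a 1.9-fold lower number from compound 1 to compound 2 (0.28 log units; within the scatter), where 2-(hydroxycarbamoyl)ethenyl replaces carboxy, and it stayed within the scatter. On that slim evidence, no step beyond the scatter is expected in this assay. The expected step is a 1.3-fold higher number from compound 2 to compound 3 (0.13 log units; within the scatter). For compound 3 the estimated value is 3500 nM, with an expected range of 1500 nM to 9000 nM.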

Compound 3, half-maximal effective concentration: 1700 nM
For compound 3 the middle estimate is 2.1-fold (0.31 log units) above the measured one, within the range that was stated.
By their numbers in this assay, from the lowest: compounds 3, 2 and 1 (each within the scatter of the next, the first and the last beyond it).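

In this assay, the end group on the carbonyl carbon can change from hydroxyamino to ethoxy, which carries no hydrogen-bond donors, with only a 1.5-fold lower number from compound 2 to compound 3 (0.18 log units; within the scatter), so the hydroxamic end does not set compound 2 apart from this ester. The change at this end of the molecule that does clear the scatter is the replacement of carboxy on the aromatic carbon by 2-(ethoxycarbonyl)ethenyl, with a 2.9-fold lower number from compound 1 to compound 3 (0.47 log units; beyond the scatter), though the step is modest. Nothing available explains either step.

As far as these compounds go, it remains open whether this step depends on the ethenyl chain or on the ethoxy group at its end, and a carboxylic acid at the end of that chain would separate the two. From the compounds shown here alone, how a methoxy group, a longer alkoxy chain or an amine on the same carbonyl carbon would stand in this assay also remains open.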